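Chloro to 2-methoxyphenyl on the shared core

A few compounds are considered here, and "the series" means these few. Any claim that something is new, unique, unknown or untested is made for them only; others in the source may bear on it.

Measured in an ADME assay on L1210/0 cells (Mus musculus) for cytotoxicity, with a stated time of 48 h; a higher number here means a weaker inhibitor, a lower number a stronger inhibitor:
- Compound 1 `COc1ncnc2c1ncn2C[C@@H]1C[C@H](O)c2ccccc21`: > 200000 nM
- Compound 2 `O[C@H]1C[C@@H](Cn2cnc3c(Cl)ncnc32)c2ccccc21`: > 200000 nM

Compound 2 gives > 200000 nM, which is a limit of the assay and not a number. It shares this position with compound 1, as the limit of > 200000 nM in this assay, at which 2 of the 2 values shown sit, shows. Neither compound therefore has a measured potency. Compound 3 `COc1ccccc1-c1ncnc2c1ncn2C[C@@H]1C[C@H](O)c2ccccc21` carries a 2-methoxyphenyl in place of chloro on an aromatic carbon, a much larger group: 2-methoxyphenyl in place of chloro on an aromatic carbon. Among the compounds with values here, the only measured step, a step that the two limits leave unreadable from compound 1 to compound 2, gives no size to build on, and no measured step covers this exchange. With so little to go on, only a modest move towards a stronger inhibitor in this assay is expected, and compound 3 may well stay at the limit. The expected change is an at least 1.3-fold lower number from compound 2 to compound 3 (0.12 log units; that floor lies within the scatter). Compound 3 is estimated at about 150000 nM, with an expected range of 40000 nM to 300000 nM.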

Compound 3, half-maximal inhibitory concentration: > 200000 nM
Compound 3 was reported as a limit; the forecaster's own chance of this, stated with the estimate: 65%; middle value at least 1.3-fold (0.12 log units) away from the limit.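

Within the data shown here, compound 3 also gives a limit and not a number, so no step among compound 1, compound 2 and compound 3 can be read: the limit of > 200000 nM in this assay, at which 3 of the 3 values shown sit. From the compounds shown here alone, whether methoxy, chloro and 2-methoxyphenyl differ at all in inhibitor strength stays open.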